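Swapping one ring group on a growth inhibitor

The source may hold more compounds than are shown below. What is called first, only, known or untested is meant among the compounds shown, and "the series" means these compounds.

Within the data shown here, in a functional assay on DU-145 cells (Homo sapiens) for inhibition, read by trypan blue exclusion, with a stated time of 96 h (on this read-out lower numbers stand for stronger inhibition of growth and higher numbers for weaker inhibition of growth), compound 1 `O=C(/C(=C\c1ccc([N+](=O)[O-])c(O)c1)SCc1ccc(Br)cc1)c1ccc([N+](=O)[O-])c(Cl)c1` gives 1000 nM, the lower of the two numbers so far. Compound 2 `COc1ccccc1/C=C(/SCc1ccc(C)cc1)C(=O)c1ccc(Cl)cc1` gives 10000 nM, a gap beyond the scatter. Compound 3 `O=C(/C(=C\c1ccc([N+](=O)[O-])c(O)c1)SCc1ccc(Br)cc1)c1ccc(Br)cc1` has 4-bromophenyl in place of 3-chloro-4-nitrophenyl on a carbonyl carbon. Among the measured compounds shown here, no measured pair of compounds shows this change alone, so any expectation remains loose. A modest move toward weaker inhibition is expected, with an estimated step of a 2.5-fold higher number from compound 1 to compound 3 (0.40 log units; beyond the scatter). In this assay, the estimate for compound 3 is 2500 nM, with an expected range from 700 nM to 10000 nM.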

Compound 3, concentration for 50% growth inhibition: 10000 nM
Compound 3: middle estimate off by 4.0-fold (0.60 log units), on the low side; the measured number falls inside the stated range.
By their numbers in this assay, from the lowest: compound 1; then compounds 2 and 3 (each within the scatter of the next).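

At the carbonyl carbon, the choice of ring group clearly counts in this assay: 4-bromophenyl in place of 3-chloro-4-nitrophenyl gives a 10-fold higher number from compound 1 to compound 3 (1.00 log units; beyond the scatter) with the rest of the molecule unchanged. The earlier compounds shown here could not show this, as they differ in more than one place. Nothing measured here accounts for the step.

The swap changes the chloro and nitro groups together, leaving open which of them counts, if either does alone. On these data alone, how an amine or a carboxylic acid on this ring would read also remains open.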